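Benzyl ester in place of cyclohexylmethyl ester

A few compounds are considered here, and "the series" means these few. Any claim that something is new, unique, unknown or untested is made for them only; others in the source may bear on it.

Of the compounds shown here, two sharing one core have been measured in an assay on isolated protein for inhibition of Voltage-dependent L-type calcium channel subunit alpha-1C (Cavia porcellus) (on this read-out higher numbers stand for weaker inhibition and lower numbers for stronger inhibition), so far. Compound 1 `CCOC(=O)C1=C(C)NC(C)=C(C(=O)OC)C1c1[nH]cnc1Cl` gives 661 nM in this assay. Compound 2 `COC(=O)C1=C(C)NC(C)=C(C(=O)OCC2CCCCC2)C1c1[nH]cnc1Cl` gives 355 nM in this assay, the lowest of the two numbers, and its nearest neighbour is compound 1, separated by a 1.9-fold lower number from compound 1 to compound 2 (0.27 log units; within the scatter), a gap that stays within the scatter.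

Compound 3 `COC(=O)C1=C(C)NC(C)=C(C(=O)OCc2ccccc2)C1c1[nH]cnc1Cl` has not yet been measured. It differs from compound 2 in one place: phenyl in place of cyclohexyl on a saturated chain carbon bound to an oxygen next to a carbonyl group. Going by the values given here, no measured step replaces a cyclohexyl with a phenyl; the only step available, the one from compound 1 to compound 2, exchanges a methyl for a cyclohexyl at the same place and stays within the scatter. Nothing in the two measured numbers therefore points to a step beyond the scatter in either direction in this assay.

Compound 3 is accordingly expected to give a number close to that of compound 2, with an estimated step of a 1.2-fold lower number from compound 2 to compound 3 (0.07 log units; within the scatter). The estimate for compound 3 in this assay is 300 nM, within a range from 100 nM to 1000 nM.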

Compound 3, half-maximal inhibitory concentration: 93.3 nM
Compound 3: middle estimate off by 3.2-fold (0.51 log units), on the high side; the whole stated range lies above it.
By their numbers in this assay, from the lowest: compound 3; then compounds 2 and 1 (each within the scatter of the next).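

In this assay this position proves sensitive to the kind of ring it carries: exchanging cyclohexyl for phenyl gives a 3.8-fold lower number from compound 2 to compound 3 (0.58 log units; beyond the scatter) even though both groups have the same count of heavy atoms, all carbon, and neither has a hydrogen-bond donor or acceptor. Compared with the methyl group at the same place, phenyl gives a 7.1-fold lower number from compound 1 to compound 3 (0.85 log units; beyond the scatter) whereas cyclohexyl had stayed within the scatter, so among these three compounds a ring alone does not separate a compound from the others, and only the aromatic ring does so. No measurement shown here bears on why the aromatic ring gives the lower number.

As far as these compounds go, it remains open whether the lower number survives on a longer chain, such as phenethyl, or with a pyridyl ring, or with a phenyl carrying a methoxy group or a chlorine atom. Going by these compounds alone, it also remains open whether the same exchange of cyclohexyl for phenyl would give a similar step on a core other than the one these three compounds share.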